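Acetamido addition on a second linker length

This account rests on a few compounds, and the source may have more. Where it says the series, first, only, none or still open, it means among the compounds named here.

Measured so far:
- compound 1 `COc1cc2ccc(=O)oc2cc1OCCCOc1no[n+]([O-])c1S(=O)(=O)c1ccccc1`: 2900 nM
- compound 2 `COc1cc2ccc(=O)oc2cc1OCCCCOc1no[n+]([O-])c1S(=O)(=O)c1ccccc1`: 3250 nM
- compound 3 `COc1cc2cc(NC(C)=O)c(=O)oc2cc1OCCCOc1no[n+]([O-])c1S(=O)(=O)c1ccccc1`: 2820 nM

All three numbers come from a functional assay on HepG2 cells (Homo sapiens) for inhibition, read by MTT assay, with a stated time of 48 h; a higher number here means a weaker inhibitor, a lower number a stronger inhibitor. Among the compounds with values here, compound 1, compound 2 and compound 3 sit close together; no step among them is printed as beyond the scatter, so no order among them is claimed here.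

Within the data shown here, the one change that is measured is acetamido in place of hydrogen on an aromatic carbon. Its size in this assay is a 1.0-fold lower number from compound 1 to compound 3 (0.01 log units; within the scatter), which leaves the number essentially where it stood. The cores of compound 1 and compound 2 differ, but that difference between the two cores is not broken down here; the two values, compound 1 at 2900 nM and compound 2 at 3250 nM, lie within the scatter of each other.

Compound 4 `COc1cc2cc(NC(C)=O)c(=O)oc2cc1OCCCCOc1no[n+]([O-])c1S(=O)(=O)c1ccccc1` is not yet measured. It carries the same change from compound 2 that compound 3 carries from compound 1: acetamido in place of hydrogen on an aromatic carbon. The place line is the same word for word in both cases, so this is taken as the same change. Because that change gave a 1.0-fold lower number from compound 1 to compound 3 (0.01 log units; within the scatter), compound 4 is expected to show a step of about a 1.0-fold lower number from compound 2 to compound 4 (0.01 log units; within the scatter) in this assay from compound 2, that is, no step outside the scatter. This rests on a single measured pair, compound 1 and compound 3, and on nothing else.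

For compound 4 the estimated value in this assay is 3150 nM, with a range of 1600 nM to 6300 nM.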

Compound 4, half-maximal inhibitory concentration: 3290 nM
The estimate for compound 4 lay 1.0-fold (0.02 log units) below the measured number; the measured number falls inside the stated range.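

On the core of compound 2, acetamido in place of hydrogen on an aromatic carbon gives a 1.0-fold higher number from compound 2 to compound 4 (0.01 log units; within the scatter) in this assay, so the addition leaves this core much as the same addition left the core of compound 1. Set side by side, the two steps do not differ, and in this small set the change carries from one core to the other as a step that stays inside the scatter: the same change on two cores in this assay, a 1.0-fold lower number (0.01 log units; within the scatter) from compound 1 to compound 3 and a 1.0-fold higher number (0.01 log units; within the scatter) from compound 2 to compound 4, 1.0-fold (0.02 log units) apart, within the scatter of two such steps

This shows only that acetamido at this place is tolerated on these two cores in this one cell assay, on the evidence of two matched pairs; with neither step beyond the scatter, it does not show that an effect of measurable size transfers between cores, and it cannot be extended to other cores, other cell lines or other exposure times.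

The compounds shown leave open whether a free amine, a carboxylic acid or a longer acyl amide on that same aromatic carbon would move the number beyond the scatter. They also leave open whether a longer chain between the shared core and the sulfonyl-bearing ring would do so, and whether any such result would carry between cores as acetamido does here.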